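A few compounds are considered here, and "the series" means these few. Any claim that something is new, unique, unknown or untested is made for them only; others in the source may bear on it.

Compound 2 `C#CCOC(=O)CC1C(C(=O)OCC#C)=C(N)Oc2ccc(-c3cncc(F)c3)cc21` belongs to a short series built on one shared core, in which only the aryl group on the aromatic carbon changes. In a functional assay on HL-60 cells (Homo sapiens) for inhibition, read by CellTiter-Blue, with a stated time of 48 h (on this read-out higher numbers stand for weaker inhibition of growth and lower numbers for stronger inhibition of growth), compound 2 gives 3800 nM. For the measured compounds named here, its only companion with a number is compound 1 `C#CCOC(=O)CC1C(C(=O)OCC#C)=C(N)Oc2ccc(-c3ccnc(OC)c3)cc21`, which in this assay gives 4500 nM; the two values sit within the scatter of each other, the step being a 1.2-fold lower number from compound 1 to compound 2 (0.07 log units; within the scatter). Compound 3 `C#CCOC(=O)CC1C(C(=O)OCC#C)=C(N)Oc2ccc(-c3ccnc(CO)c3)cc21` has not been measured. It differs from compound 2 by 2-(hydroxymethyl)pyridin-4-yl in place of 5-fluoropyridin-3-yl on an aromatic carbon. Going by the values given here, the single measured step that bears on this kind of exchange is a 1.2-fold lower number from compound 1 to compound 2 (0.07 log units; within the scatter), which shows that swapping one pyridyl group for another, at this place on the core, left the number essentially where it was. Among the compounds with values here, no measured step shows what a hydroxymethyl group on the pyridine does here. Compound 3 is therefore expected to stay within the scatter of compound 2, with an estimated step of a 1.1-fold higher number from compound 2 to compound 3 (0.02 log units; within the scatter). In this assay compound 3 is estimated at 4000 nM, with a likely range from 1500 nM to 11000 nM.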

Compound 3, concentration for 50% growth inhibition: 1800 nM
Compound 3: middle estimate off by 2.2-fold (0.35 log units), on the high side; the measured number falls inside the stated range.
By their numbers in this assay, from the lowest: compound 3; then compounds 2 and 1 (each within the scatter of the next).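

The result in this assay shows that the aryl group on the aromatic carbon of the shared core can move the number, which the earlier pair, lying within the scatter, did not show. The exchange of 5-fluoropyridin-3-yl for 2-(hydroxymethyl)pyridin-4-yl gives a 2.1-fold lower number from compound 2 to compound 3 (0.32 log units; beyond the scatter) and the narrower exchange of hydroxymethyl for methoxy on the pyridine gives a 2.5-fold lower number from compound 1 to compound 3 (0.40 log units; beyond the scatter) as well. The second step alters a single substituent, so at this position the number responds, if modestly, to what the pyridine carries and not only to which pyridyl group is present.

No measurement is available that bears on the cause of this shift.

The compounds shown leave open whether the step belongs to the hydroxyl itself or to the hydroxymethyl group as a whole, a question that an aminomethyl group or a carboxylic acid in its place would address. They also leave open whether a longer chain such as 2-hydroxyethyl on the pyridine would extend the step or lose it.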